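The source may hold more compounds than are shown below. What is called first, only, known or untested is meant among the compounds shown, and "the series" means these compounds.

Compound 1 `COc1ccc2nc(C)cc(OCC(=O)Nc3ccc(Cl)cc3Cl)c2c1` gives in a toxicity assay on HepG2 cells (Homo sapiens) for inhibition, read by CellTiter-Glo, with a stated time of 48 h (on this read-out lower numbers stand for stronger inhibition and higher numbers for weaker inhibition), only a limit, > 100000 nM.
Compound 2 `COc1ccc2nc(C)cc(OCC(=O)Nc3ccc(Cl)c(OC)c3)c2c1` gives in this assay only a limit, > 100000 nM.

On the numbers shown, compound 2 stands at a limit of this assay rather than at a measured value, and the one other value shown is a limit as well. The step from compound 1 to compound 2 is a step that the two limits leave unreadable from compound 1 to compound 2; both values sit at the limit of > 100000 nM in this assay, at which 2 of the 2 values shown sit. Compound 3 `COc1ccc2nc(C)cc(OCC(=O)Nc3c(C)cncc3C)c2c1` differs from compound 2 by 3,5-dimethylpyridin-4-yl in place of 4-chloro-3-methoxyphenyl on an amide-type nitrogen. For the measured compounds named here, the only measured step that bears on this change is the one from compound 1 to compound 2, and its size is not readable, so neither a direction nor a size beyond the scatter can be taken from it. Compound 3 is therefore expected to show a step of a number no higher from compound 2 to compound 3 (the limit leaves the size open) in this assay. The estimate for compound 3 in this assay is 100000 nM, with a range from 30000 nM to 300000 nM, and most likely reported again only as a limit.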

Compound 3, half-maximal inhibitory concentration: 12600 nM
The estimate for compound 3 lay 7.9-fold (0.90 log units) above the measured number; measured number outside the range, below it.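

At this place, on an amide-type nitrogen, the group does move the read-out in this assay: 3,5-dimethylpyridin-4-yl in place of 4-chloro-3-methoxyphenyl gives an at least 7.9-fold lower number from compound 2 to compound 3 (0.89 log units; beyond the scatter), and in place of 2,4-dichlorophenyl it gives an at least 7.9-fold lower number from compound 1 to compound 3 (0.89 log units; beyond the scatter). Compound 3 is the only one of the three with a measured number rather than a limit, and the step between compound 1 and compound 2 cannot be read. Both new steps are minimum sizes, because compound 1 and compound 2 stand at a limit: the limit of > 100000 nM in this assay, at which 2 of the 3 values shown sit.

As far as these compounds go, whether the ring nitrogen or the two methyl groups of 3,5-dimethylpyridin-4-yl carry the step remains open. For the compounds shown here, also open is how a pyridine ring without methyl groups, or a phenyl ring with only two methyl groups, would read on the same nitrogen.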